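Tolyl for Indolyl in a Biphenylsulfonamide Series

A few compounds are considered here, and "the series" means these few. Any claim that something is new, unique, unknown or untested is made for them only; others in the source may bear on it.

Compound 3 `O=S(=O)(Nc1cccc(CO)c1)c1ccc(-c2ccc3cc[nH]c3c2)cc1` was examined in a functional assay on J774 cells (Mus musculus) for cytotoxicity, read by resazurin assay, with a stated time of 72 h (a higher number here means a weaker inhibitor, a lower number a stronger inhibitor), and in that assay compound 3 gives 2500 nM. At the digits recorded this is level with compound 2 `O=S(=O)(Nc1cc(CO)cc(CO)c1)c1ccc(-c2ccc(Cl)cc2Cl)cc1`, which in this assay gives 2500 nM; the two together hold the highest numbers of the three measured, and the difference between them lies within the scatter. Compound 1 `O=S(=O)(Nc1cc(CO)ccc1O)c1ccc(-c2ccc(F)cc2F)cc1` stands furthest from compound 3: in this assay compound 1 gives 200 nM, a markedly lower number and a gap well beyond the scatter.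

Compound 4 `Cc1ccc(-c2ccc(S(=O)(=O)Nc3cccc(CO)c3)cc2)cc1` differs from compound 3 in one place: 4-methylphenyl in place of 1H-indol-6-yl on an aromatic carbon. Within the data shown here, no pair of measured compounds shares this exact change, so its size is not known from the data. Compound 1 also carries a substituted phenyl at this aromatic carbon and gives 200 nM, but compound 1 differs from compound 3 elsewhere as well, so that number is only a loose guide. The step from compound 3 to compound 4 is expected to be a modest lowering, a 1.7-fold lower number from compound 3 to compound 4 (0.22 log units; within the scatter), possibly not beyond the scatter. Compound 4 is therefore estimated to give 1500 nM, with a range from 400 nM to 6000 nM.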

Compound 4, half-maximal inhibitory concentration: 1200 nM
For compound 4 the middle estimate is 1.3-fold (0.10 log units) above the measured one; the range from low to high includes it.
By their numbers in this assay, from the lowest: compound 1; then compound 4; then compounds 2 and 3 (each within the scatter of the next).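

In this assay, among these compounds, replacing 1H-indol-6-yl with 4-methylphenyl gives a 2.1-fold lower number from compound 3 to compound 4 (0.32 log units; beyond the scatter), the first step in this set read between compounds that differ in one place. It shows that, at this aromatic carbon para to a large group, the number does not rise when the two-ring group with its hydrogen-bond donor gives way to a single six-membered aromatic ring of carbon only carrying a methyl group; the shift is modest but lies beyond the scatter. Nothing at hand accounts for the size or direction of this step.

A single step leaves open whether the lower number follows from the methyl group or from the loss of the 1H-indol-6-yl group, as both changes arrive together, and a plain phenyl, a 4-methoxyphenyl or a 4-aminophenyl at the same carbon would help to separate these two readings. On these data alone, it also remains open whether the same exchange would give a step of similar size on the core of compound 1 or compound 2, where the other ring carries different groups.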